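Ring size on the amide nitrogen: cyclobutyl to cyclopentyl

The compounds below may be only part of what the source reports. "The series", "measured", "known", "first", "only" and "open" are said of these compounds alone.

Among the measured compounds shown here, in a functional assay on HEK293 cells for antagonist activity at solute carrier family 12 member 5 (Homo sapiens), read by fluorescence, with a stated time of 8 min (a higher number here means a weaker inhibitor, a lower number a stronger inhibitor), compound 2 `Cc1csc(N(C(=O)CSc2ccc(-c3ccccc3)nn2)C2CCC2)n1` gives 177 nM, the lowest of the two numbers so far. For the measured compounds named here, compound 1 `Cc1csc(NC(=O)CSc2ccc(-c3ccccc3)cn2)n1` gives 6900 nM in this assay, a gap beyond the scatter, but no single-place step connects these two compounds. Compound 3 `Cc1csc(N(C(=O)CSc2ccc(-c3ccccc3)nn2)C2CCCC2)n1` carries cyclopentyl in place of cyclobutyl on an amide-type nitrogen. Going by the values given here, no measured pair covers this change. The step expected here, a 1.2-fold lower number from compound 2 to compound 3 (0.07 log units; within the scatter), is small and within the scatter, with no clear direction. For compound 3 in this assay the estimate is 150 nM, with a range of 60 nM to 400 nM.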

Compound 3, half-maximal inhibitory concentration: 1060 nM
Estimate against measurement, compound 3: 7.1-fold (0.85 log units) below; the measured number lies above the stated range.
By their numbers in this assay, from the lowest: compound 2; then compound 3; then compound 1.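

In this assay, among the compounds shown here, cyclopentyl in place of cyclobutyl on the amide-type nitrogen gives a 6.0-fold higher number from compound 2 to compound 3 (0.78 log units; beyond the scatter) as the first single-place step. A single added ring carbon at this position therefore moves the number beyond the scatter, and the two rings are not interchangeable here. No measurement shown offers an explanation for this step.

Still open, going by these compounds, is whether cyclopropyl or an open chain such as isopropyl on this nitrogen would match or improve on compound 2. The effect of an amine or ether oxygen in the ring is also unresolved.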